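The source may hold more compounds than are shown below. What is called first, only, known or untested is meant among the compounds shown, and "the series" means these compounds.

Measured in a functional assay on the whole organism (strain Kunming) with Mus musculus as the target, with a stated time of 0.5 h; a higher number here means that more compound is needed for the effect, a lower number that less compound is needed:
- compound 1 `COc1cc(OC)c(OC)cc1/C=C/COC(=O)/C=C/c1ccccc1Cl`: 151 umol/kg
- compound 2 `COc1cccc(/C=C/C(=O)OC/C=C/c2cc(OC)c(OC)cc2OC)c1`: 190 umol/kg

Among the measured compounds shown here, only these two compounds have numbers so far, and they cannot be told apart. Compound 2 at 190 umol/kg lies within the scatter of compound 1 at 151 umol/kg.

The next compound, compound 3 `COc1ccc(/C=C/C(=O)OC/C=C/c2cc(OC)c(OC)cc2OC)cc1`, has the same atoms as compound 2, joined differently: 4-methoxyphenyl in place of 3-methoxyphenyl on a double-bonded chain carbon bound to a double-bonded chain carbon. It carries 4-methoxyphenyl in place of 3-methoxyphenyl on a double-bonded chain carbon bound to a double-bonded chain carbon.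

For the measured compounds named here, one measured step bears on this change. At that same place, 3-methoxyphenyl in place of 2-chlorophenyl gave a 1.3-fold higher number from compound 1 to compound 2 (0.10 log units; within the scatter), a small step that stays within the scatter. Going by the values given here, no measured compound yet carries 4-methoxyphenyl, so this evidence is indirect and thin. Even so, the only exchange seen at this place moved this assay by no more than the scatter, so no real shift in either direction is expected.

The expected change is a 1.1-fold lower number from compound 2 to compound 3 (0.04 log units; within the scatter), which is no step beyond the scatter.

Compound 3 is estimated at 175 umol/kg, with an expected range from 85 umol/kg to 350 umol/kg.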

Compound 3, dose for half-maximal effect: 184 umol/kg
Compound 3: the middle estimate sits 1.1-fold (0.02 log units) below what was measured, and the stated range covers the measured number.
By their numbers in this assay, from the lowest: compounds 1, 3 and 2 (each within the scatter of the next).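

In this assay, the exchange of 3-methoxyphenyl for 4-methoxyphenyl on a double-bonded chain carbon bound to a double-bonded chain carbon gave a 1.0-fold lower number from compound 2 to compound 3 (0.01 log units; within the scatter), so joining the same atoms differently at this place produced no readable difference, a kind of change the earlier pair did not cover. The exchange of 2-chlorophenyl for 4-methoxyphenyl at the same place gave a 1.2-fold higher number from compound 1 to compound 3 (0.09 log units; within the scatter), which adds a second exchange from 2-chlorophenyl that stays within the scatter, and all three compounds now cannot be told apart in this assay. Nothing further is available that would help to interpret these numbers.

As far as these compounds go, all three compounds carry a substituted phenyl group at this place, so it remains open whether an amine, a carboxylic acid or a longer chain there would move the number beyond the scatter. The rest of the shared core is identical in compound 1, compound 2 and compound 3, so these results say nothing about how changes elsewhere in the core would affect this assay.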